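Another Aromatic Group on the Ring Nitrogen of Compound 2

The source may report more compounds than this note shows. Statements on the series, on what has been measured and on what is new or still open speak of the compounds shown alone.

Compound 1 `CCC1(CCCCN2CCN(c3cccc(Cl)c3)CC2)C(=O)Nc2cc(F)ccc21` gives > 20 mg/kg in a functional assay on the whole organism (strain Wistar) with Rattus norvegicus as the target, with a stated time of 5 min (on this read-out lower numbers stand for an effect already at smaller amounts and higher numbers for an effect only at larger amounts of compound), which is a limit of the assay and not a number.
Compound 2 `CCC1(CCCCN2CCN(c3cccc(Cl)c3)CC2)C(=O)Nc2ccccc21` gives > 20 mg/kg in this assay, again only a limit.
Compound 3 `O=C1Nc2ccccc2C1CCCCN1CCN(c2cccc(Cl)c2)CC1` gives < 5 mg/kg in this assay, also a limit.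

Compound 2 thus sits at the upper limit, together with compound 1 (the limit of > 20 mg/kg in this assay, at which 2 of the 3 values shown sit), while compound 3 alone reaches the lower limit (the limit of < 5 mg/kg in this assay, at which 1 of the 3 values shown sits). Of the two measured steps, a step that the two limits leave unreadable from compound 1 to compound 2 cannot be read at all, and an at least 4.0-fold lower number from compound 2 to compound 3 (0.60 log units; beyond the scatter) concerns hydrogen in place of ethyl on a saturated ring carbon. Compound 4 `CCC1(CCCCN2CCN(c3ccccc3OC)CC2)C(=O)Nc2ccccc21` changes compound 2 in a different place: 2-methoxyphenyl in place of 3-chlorophenyl on an amine nitrogen in a ring. Neither measured step touches the aromatic group on the ring nitrogen, so none of them bears on this change, and its size in this assay cannot be taken from the measured data. Compound 4 is therefore expected to stay close to compound 2, with a number no higher from compound 2 to compound 4 (the limit leaves the size open) as the estimated step. For compound 4 the estimated value in this assay is 20 mg/kg, expected to lie between 7 mg/kg and 50 mg/kg.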

Compound 4, minimum effective dose: 10 mg/kg
Estimate against measurement, compound 4: 2.0-fold (0.30 log units) above; the measured number falls inside the stated range.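

In this assay compound 4 gives 10 mg/kg, a true number and not a limit, even though it keeps the ethyl group. So the ethyl group alone does not hold a compound at the upper limit, and the aromatic group on the ring nitrogen, untouched by the earlier steps, can also shift the result. Replacing 3-chlorophenyl with 2-methoxyphenyl gives an at least 2.0-fold lower number from compound 2 to compound 4 (0.30 log units; that floor lies within the scatter), so this floor alone does not establish a real gain.

On these data alone, the true size of the step stays open because compound 2 sits at a limit: the limit of > 20 mg/kg in this assay, at which 2 of the 4 values shown sit. Also open, as far as these compounds go, is whether the same swap would act alike in compound 3, which has hydrogen instead of ethyl, and how an unsubstituted phenyl group or a pyridyl group on that nitrogen would compare.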